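Swapping the benzyl ring substituent in a series of anilide antagonists

This account rests on a few compounds, and the source may have more. Where it says the series, first, only, none or still open, it means among the compounds named here.

Measured so far:
- compound 1 `COc1cc(N)c(Cl)cc1NC(=O)C1CCN(Cc2ccc(Cl)cc2)CC1`: 1.2 mg/kg
- compound 2 `COc1cc(N)c(Cl)cc1NC(=O)C1CCN(CC2CCCC2)CC1`: > 10 mg/kg
- compound 3 `COc1cc(N)c(Cl)cc1NC(=O)C1CCN(Cc2cccc(C#N)c2)CC1`: > 4 mg/kg

The three compounds share a core and differ only in the group on a saturated chain carbon bound to an amine nitrogen in a ring. In a functional assay on the whole organism for antagonist activity, with Mus musculus as the target (on this read-out lower numbers stand for an effect already at smaller amounts and higher numbers for an effect only at larger amounts of compound), compound 1 gives 1.2 mg/kg. For compound 2 the read-out is only a limit, > 10 mg/kg. For compound 3 the read-out is likewise only a limit, > 4 mg/kg, so compound 3 stands at the limit of > 4 mg/kg in this assay, at which 1 of the 3 values shown sits, and no exact number is known for it. The measured steps place compound 1 clearly ahead: an at least 3.3-fold higher number from compound 1 to compound 3 (0.52 log units; beyond the scatter) and an at least 8.3-fold higher number from compound 1 to compound 2 (0.92 log units; beyond the scatter), while a step that the two limits leave unreadable from compound 2 to compound 3.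

Compound 4 `COc1cc(N)c(Cl)cc1NC(=O)C1CCN(Cc2ccc([N+](=O)[O-])cc2)CC1` changes compound 3 as follows: 4-nitrophenyl in place of 3-cyanophenyl on a saturated chain carbon bound to an amine nitrogen in a ring. Both 3-cyanophenyl and 4-nitrophenyl are aromatic rings carrying a polar substituent, and the change of 4-chlorophenyl to 3-cyanophenyl already weakened the effect. Compound 4 is therefore expected to remain near the weaker end, with an estimated step that the limit leaves unreadable from compound 3 to compound 4 that is small. The estimate for compound 4 in this assay is 5 mg/kg, ranging from 1.5 mg/kg to 15 mg/kg.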

Compound 4, dose for half-maximal effect: > 4 mg/kg
Compound 4: no number, only a limit; the forecaster's own chance of this, stated with the estimate: 50%; the middle value does not contradict the limit.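

In this assay, the exchange of chloro for nitro on an aromatic carbon gives an at least 3.3-fold higher number from compound 1 to compound 4 (0.52 log units; beyond the scatter). Compound 3 had replaced 4-chlorophenyl with a different substituted ring, whereas compound 4 shows that changing the chloro group alone is enough to lose the result of compound 1, with the rest of the molecule unchanged. The read-outs of compound 3 and compound 4 are limits rather than numbers, so no step among compounds 2, 3 and 4 can be read and these compounds cannot be ranked: the limit of > 4 mg/kg in this assay, at which 2 of the 4 values shown sit.

As far as these compounds go, how far compounds 2, 3 and 4 truly lie from compound 1 remains open. From the compounds shown here alone, it is also open whether chloro is unusual at this place, or whether a 4-methylphenyl or 4-methoxyphenyl group would give a measurable number in this assay.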